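This account rests on a few compounds, and the source may have more. Where it says the series, first, only, none or still open, it means among the compounds named here.

Within the data shown here, in a functional assay on HT-29 cells (Homo sapiens) for inhibition, read by luminescence and CellTiter-Glo, with a stated time of 24 h (on this read-out lower numbers stand for an effect already at smaller amounts and higher numbers for an effect only at larger amounts of compound), compound 2 `CN1C(=S)[C@@H](NC(=O)c2nc(Cc3ccccc3)n(CCC(F)(F)F)n2)COc2ccccc21` gives 1550 nM, the higher of the two numbers known so far. The other belongs to compound 1 `COCCn1nc(C(=O)N[C@H]2COc3ccccc3N(C)C2=S)nc1Cc1ccccc1`, at 566 nM. Compound 3 `CN1C(=S)[C@@H](NC(=O)c2nc(Cc3ccccc3)n(CCCC(F)(F)F)n2)COc2ccccc21` turns the 3,3,3-trifluoropropyl of compound 2 into 4,4,4-trifluorobutyl, with 2,2,2-trifluoroethyl in place of trifluoromethyl on a saturated chain carbon, two bonds along the chain from an aromatic nitrogen. Among the measured compounds shown here, only one measured step bears on this chain, a modest one, a 2.7-fold higher number from compound 1 to compound 2 (0.44 log units; beyond the scatter). A change of no greater size is therefore expected, with no firm direction and perhaps nothing beyond the scatter. The expected step is a 1.1-fold higher number from compound 2 to compound 3 (0.04 log units; within the scatter). For compound 3 the estimate is 1700 nM, with an expected range of 650 nM to 4500 nM.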

Compound 3, half-maximal effective concentration: 2380 nM
Compound 3: middle estimate off by 1.4-fold (0.15 log units), on the low side; low and high end bracket the measured number.
By their numbers in this assay, from the lowest: compound 1; then compounds 2 and 3 (each within the scatter of the next).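

In this assay, going from 3,3,3-trifluoropropyl to 4,4,4-trifluorobutyl gives a 1.5-fold higher number from compound 2 to compound 3 (0.19 log units; within the scatter), so lengthening the fluorinated chain at this position brings no change that can be told from the scatter. The gap to the methoxy-bearing chain of compound 1 remains, with a 4.2-fold higher number from compound 1 to compound 3 (0.62 log units; beyond the scatter), so both fluorinated chains stand apart from it beyond the scatter. No evidence here explains that gap. From the compounds shown here alone, whether a chain ending in an amine or a carboxylic acid would match or better compound 1 stays open, as does whether a still longer fluorinated chain would move the number beyond the scatter.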